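A few compounds are considered here, and "the series" means these few. Any claim that something is new, unique, unknown or untested is made for them only; others in the source may bear on it.

Measured compounds in an ADME assay on RAW264.7 cells (Mus musculus) for cytotoxicity, read by MTT assay, with a stated time of 24 h, in the presence of a further agent that is not named here; a higher number here means a weaker inhibitor, a lower number a stronger inhibitor:

compound 1, `O=C1OC(Cc2nc(-c3ccc(-c4ccccc4)cc3)no2)c2ccccc21`, gives > 40000 nM; this is a limit of the assay, not a number.
compound 2, `CCCCCCOc1ccc(C(O)C2OC(=O)c3c(OC)cc(OC)cc32)cc1`, gives > 40000 nM; this too is a limit of the assay, not a number.

Going by the values given here, compound 2 therefore stands at the limit in this assay, with no numerical value to rank it, and the one other value shown is a limit as well: the limit of > 40000 nM in this assay, at which 2 of the 2 values shown sit. No step between measured compounds is available, so nothing in the numbers shown points to a direction for the next change.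

Compound 3, `COc1cc(OC)c2c(c1)C(C(O)c1ccc(OCc3ccc(Cl)cc3)cc1)OC2=O`, differs from compound 2 as follows: 4-chlorophenyl in place of pentyl on a saturated chain carbon bound to an oxygen on an aromatic ring. With both measured values sitting at the limit, the expectation for this assay is no step beyond the usual scatter, in either direction, and most likely a third limit. The step from compound 2 to compound 3 is estimated as a step that the limit leaves unreadable from compound 2 to compound 3. For compound 3 in this assay the expected value is 60000 nM, with a range from 20000 nM to 200000 nM.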

Compound 3, half-maximal inhibitory concentration: > 40000 nM
Compound 3 was reported as a limit (the forecaster's own chance of this, stated with the estimate: 85%); the middle value is on the limit's open side.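

In this assay compound 3 gives > 40000 nM, a limit of the assay and not a number. Compound 2 also stands at a limit, so no step can be read between compound 2 and compound 3. The compounds shown leave open whether any structural change gives a numerical value in this assay, and the series so far stands at one reading: the limit of > 40000 nM in this assay, at which 3 of the 3 values shown sit.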